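Urea-linked quinazoline series: swapping the para amine substituent

This account rests on a few compounds, and the source may have more. Where it says the series, first, only, none or still open, it means among the compounds named here.

Measured compounds:
Compound 1, `COc1ccc(Nc2ncnc3ccc(NC(=O)Nc4ccc(CN5CCN(C)CC5)cc4)cc23)cc1Cl`, in a functional assay on A549 cells (Homo sapiens) for antiproliferative activity, read by MTT assay, with a stated time of 72 h (on this read-out lower numbers stand for stronger inhibition and higher numbers for weaker inhibition), compound 1 gives 3570 nM.
Compound 2, `CN(C)Cc1ccc(NC(=O)Nc2ccc3ncnc(Nc4cccc(C(F)(F)F)c4)c3c2)cc1`, in this assay compound 2 gives 1120 nM.

Of the two measured compounds, compound 2 holds the lower number; compound 1 sits higher by a gap beyond the usual scatter, and the two differ at more than one place, so only their two values can be compared.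

Compound 3, `CCN(CC)c1ccc(NC(=O)Nc2ccc3ncnc(Nc4cccc(C(F)(F)F)c4)c3c2)cc1`, has not yet been measured. It differs from compound 2 in one place: diethylamino in place of (dimethylamino)methyl on an aromatic carbon. Among the compounds with values here, no measured pair in this set shows that change, so its effect is unknown. The account expects compound 3 to give a number near that of compound 2, with a step toward a higher number that may not exceed the scatter, and estimates a 1.6-fold higher number from compound 2 to compound 3 (0.21 log units; within the scatter) for that step. For compound 3 in this assay the estimate is 1800 nM, with a range from 600 nM to 5500 nM.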

Compound 3, half-maximal inhibitory concentration: 3520 nM
Compound 3: middle estimate off by 2.0-fold (0.29 log units), on the low side; the measured number falls inside the stated range.
By their numbers in this assay, from the lowest: compound 2; then compounds 3 and 1 (each within the scatter of the next).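

Within the data shown here, this is the first step that changes one place only. In this assay, diethylamino in place of (dimethylamino)methyl gives a 3.1-fold higher number from compound 2 to compound 3 (0.50 log units; beyond the scatter), so the number responds to what is on this aromatic carbon, para to a large group. Neither group has a ring or a net charge, and both have the same counts of hydrogen-bond donors and acceptors, so these counts do not distinguish the two, and nothing available explains the step.

The compounds shown leave open whether the step follows from losing the carbon that separates the nitrogen from the ring or from the longer ethyl groups on that nitrogen, since both differ at once. A dimethylamino or a (diethylamino)methyl group at this position would separate the two, and a piperidine or a carboxylic acid would extend the comparison to other kinds of group.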